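Bromo to chloro at the inactive end of the series

This account rests on a few compounds, and the source may have more. Where it says the series, first, only, none or still open, it means among the compounds named here.

In a functional assay on HL-60 cells (Homo sapiens) for antiproliferative activity, with a stated time of 72 h (on this read-out higher numbers stand for weaker inhibition of growth and lower numbers for stronger inhibition of growth), compound 2 `C=C(C)C(=O)c1ccc(OC(C)C(=O)O)cc1Br` reads > 60000 nM, which is a limit and not a number. Compound 3 `C=C(CC)C(=O)c1ccc(OC(C)C(=O)O)cc1Br` reads > 60000 nM, also a limit. Going by the values given here, that leaves a step that the two limits leave unreadable from compound 2 to compound 3, so the only measured step offers no size to carry over. Among the compounds with values here, the one number in the set belongs to compound 1 `C=C(CCC)C(=O)c1ccc(OC(C)C(=O)O)c(C)c1C`, at 11200 nM, and compound 1 differs from compound 2 in more than one place.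

Compound 4 `C=C(C)C(=O)c1ccc(OC(C)C(=O)O)cc1Cl` is reached from compound 2 by chloro in place of bromo on an aromatic carbon, ortho to a (1-methylethenyl)carbonyl group. Within the data shown here, no measured step covers this exchange, and the nearest guide is the limit of > 60000 nM in this assay, at which 2 of the 3 values shown sit. No shift beyond the scatter is therefore expected in this assay, and another reading at the limit is the likeliest result. The estimated change is a number no higher from compound 2 to compound 4 (the limit leaves the size open). For compound 4 the expected value is 60000 nM, with an expected range of 30000 nM to 120000 nM.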

Compound 4, concentration for 50% growth inhibition: > 60000 nM
Compound 4 ended at the assay's limit (the forecaster's own chance of this, stated with the estimate: 70%); the middle value lies on the limit itself.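

Compound 2 and compound 4 both read as limits and not as numbers, so no new step can be read from chloro in place of bromo: the limit of > 60000 nM in this assay, at which 3 of the 4 values shown sit.

The compounds shown leave open how chloro and bromo compare on the shared core where growth inhibition reads as a number.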